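Swapping methylamino for ethoxy on compound 2

This account rests on a few compounds, and the source may have more. Where it says the series, first, only, none or still open, it means among the compounds named here.

- compound 1 `CCOC(=O)/C=C/c1ccncc1-c1ccc2c(cnn2C)c1` gives > 10000 nM (a limit)
- compound 2 `CNC(=O)/C=C/c1ccncc1-c1ccc2cc[nH]c2c1` gives 7680 nM
- compound 3 `CCOC(=O)/C=C/c1ccncc1-c1ccc2[nH]ccc2c1` gives > 10000 nM (a limit)

Within the data shown here, in a functional assay on MDA-MB-231 cells (Homo sapiens) for inhibition, read by sulforhodamine B assay, with a stated time of 72 h (on this read-out lower numbers stand for stronger inhibition of growth and higher numbers for weaker inhibition of growth), compound 2 gives 7680 nM, the only number among the three measured compounds. The other two values are limits and not numbers.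

The next compound to be measured is compound 4 `CCOC(=O)/C=C/c1ccncc1-c1ccc2cc[nH]c2c1`, which keeps the core of compound 2 and differs from it by ethoxy in place of methylamino on a carbonyl carbon. Seen one bond further out, the same change turns 2-(methylcarbamoyl)ethenyl into 2-(ethoxycarbonyl)ethenyl.

Among the measured compounds shown here, no measured pair shows this change on its own. Compound 4 shares 2-(ethoxycarbonyl)ethenyl with compound 1 and compound 3, although their cores differ from its own. Those two sit at the limit of > 10000 nM in this assay, at which 2 of the 3 values shown sit, so the expectation leans toward weaker inhibition of growth.

The expected change is small, given as a 1.3-fold higher number from compound 2 to compound 4 (0.11 log units; within the scatter) in this assay, and a reading that reports only a limit is quite possible.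

For compound 4 the estimate is 10000 nM, with an expected range from 3500 nM to 30000 nM.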

Compound 4, concentration for 50% growth inhibition: 7980 nM
Compound 4: the middle estimate sits 1.3-fold (0.10 log units) above what was measured, and the stated range covers the measured number.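

In this assay, the exchange on the carbonyl carbon can now be read on its own: ethoxy in place of methylamino gives a 1.0-fold higher number from compound 2 to compound 4 (0.02 log units; within the scatter). On the core of compound 2, the read-out therefore does not separate the methylamino group, with its hydrogen-bond donor, from the ethoxy group, and 2-(ethoxycarbonyl)ethenyl does not by itself bring a limit. Compound 1 and compound 3, which carry that same group on other cores, remain limits and not numbers: the limit of > 10000 nM in this assay, at which 2 of the 4 values shown sit.

As far as these compounds go, it remains open whether a carboxylic acid, or an ester with a longer chain, at this carbonyl carbon would move the number on the core of compound 2. From the compounds shown here alone, it is also open whether methylcarbamoyl on the cores of compound 1 and compound 3 would give a number rather than a limit.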